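A few compounds are considered here, and "the series" means these few. Any claim that something is new, unique, unknown or untested is made for them only; others in the source may bear on it.

In a functional assay on KOPN-8 cells (Homo sapiens) for antiproliferative activity, with a stated time of 72 h (a higher number here means that more compound is needed for the effect, a lower number that less compound is needed), compound 1 `COc1ccc(-c2cc(=O)c3c(OC)cc(OC)cc3n2Cc2ccccc2)cc1` gives only a limit of > 17300 nM. Compound 2 `COc1ccc(-c2cc(=O)c3c(OC)cc(OC)cc3n2S(=O)(=O)c2ccc(C)c([N+](=O)[O-])c2)cc1` also reaches only a limit in this assay, > 51700 nM. The value of compound 1 sits at the limit of > 17300 nM in this assay, at which 1 of the 2 values shown sits. The value of compound 2 sits at the limit of > 51700 nM in this assay, at which 1 of the 2 values shown sits. For the measured compounds named here, compound 2 thus stands at a limit, as does the one other measured compound, and no step between measured compounds is available. Compound 3 `COc1ccc(-c2cc(=O)c3c(OC)cc(OC)cc3n2S(=O)(=O)c2ccc(C#N)cc2)cc1` differs from compound 2 by 4-cyanophenyl in place of 4-methyl-3-nitrophenyl on a sulfonyl sulfur. With both shown values being limits, the measurements give no direction for this change. Compound 3 is expected to remain at a limit as well, so the step of an at least 1.0-fold lower number from compound 2 to compound 3 (0.01 log units; that floor lies within the scatter) is expected to be no change beyond the scatter. The estimate for compound 3 in this assay is 50000 nM, with a range from 15000 nM to 150000 nM.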

Compound 3, half-maximal effective concentration: > 17200 nM
Compound 3: no number, only a limit; the forecaster's own chance of this, stated with the estimate: 85%; the middle value lies beyond the limit too.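

In this assay compound 3 gives only a limit, > 17200 nM. Compound 1 and compound 2 also stand at limits, so neither step from them to compound 3 can be read. The compounds shown leave open whether either change alters antiproliferative activity in this assay.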